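A Longer Ester Chain and Cell Killing at One Dose

The source may hold more compounds than are shown below. What is called first, only, known or untested is meant among the compounds shown, and "the series" means these compounds.

Among the compounds with values here, compound 1 `CCCCOC(=O)CCC(=O)N1CCN(CCCOc2cc3c(Nc4ccc(F)c(Cl)c4)ncnc3cc2OC)CC1` stands highest among the three numbers measured so far in a functional assay on A549 cells (Homo sapiens) for cytotoxicity, read by MTT assay, with a stated time of 24 h, tested at 80 uM; on this read-out lower numbers stand for a stronger effect and higher numbers for a weaker effect at the one concentration tested: compound 1 gives 36.9%. Its nearest neighbour is compound 3 `CCCCCCCCOC(=O)CCC(=O)N1CCN(CCCOc2cc3c(Nc4ccc(F)c(Cl)c4)ncnc3cc2OC)CC1`, which in this assay gives 21.7%; the furthest is compound 2 `CCCCCOC(=O)CCC(=O)N1CCN(CCCOc2cc3c(Nc4ccc(F)c(Cl)c4)ncnc3cc2OC)CC1`, which in this assay gives 18.2%. The move from compound 1 to compound 2 is a step of a number 18.7 percentage points lower from compound 1 to compound 2 (beyond the scatter), and from compound 1 to compound 3 a step of a number 15.2 percentage points lower from compound 1 to compound 3 (beyond the scatter); between compound 2 and compound 3 the step is a number 3.5 percentage points higher from compound 2 to compound 3 (within the scatter).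

Compound 4 `CCCCCCCCCCCCCCOC(=O)CCC(=O)N1CCN(CCCOc2cc3c(Nc4ccc(F)c(Cl)c4)ncnc3cc2OC)CC1` has not yet been measured. It differs from compound 1 by decyl in place of hydrogen on a saturated chain carbon, four bonds along the chain from an oxygen next to a carbonyl group. The two measured steps that start from compound 1 both put a chain in place of hydrogen at the same place, and both lower the number beyond the scatter; the step from compound 2 to compound 3 lengthens the chain further and stays within the scatter. A lower number is therefore expected for compound 4, of roughly the size seen before, though with a wider spread of uncertainty. The expected step is a number 14.9 percentage points lower from compound 1 to compound 4 (beyond the scatter). The estimate for compound 4 in this assay is 22%, between 8% and 40%.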

Compound 4, a percentage reported as activity, at one concentration (the size of the read-out at that concentration, not a potency): 77.2%
Estimate against measurement, compound 4: 55.2 percentage points below; the measured number lies above the stated range.
By their numbers in this assay, from the lowest: compounds 2 and 3 (each within the scatter of the next); then compound 1; then compound 4.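

Lengthening the chain at this position does not keep lowering the number in this assay: the added decyl takes it the other way, a number 40.3 percentage points higher from compound 1 to compound 4 (beyond the scatter), whereas the chains of compound 2 and compound 3 both gave numbers lower than compound 1. The reversal is larger still against those two shorter-chain compounds, a number 55.5 percentage points higher from compound 3 to compound 4 (beyond the scatter) and a number 59 percentage points higher from compound 2 to compound 4 (beyond the scatter), so the effect of chain length here runs in no single direction, and compound 4 is the one that breaks the earlier downward step. No measurement at hand bears on why the number turns upward at this chain length.

On these data alone, the point at which the number turns remains open, and an ester with a chain lying in length between those of compound 3 and compound 4, such as a dodecyl ester, would help to place it. Also open, as far as these compounds go, is how the read-out would respond to a chain of similar length ending in an amine or a carboxylic acid, or to a still longer chain.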